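Methyl for Fluoro on the Aryl Ring of Compound 2

This account rests on a few compounds, and the source may have more. Where it says the series, first, only, none or still open, it means among the compounds named here.

Compounds measured so far:
Compound 1, `CC1(C)[C@H]2CC[C@]1(C)N(Cc1cn(-c3ccccc3Br)nn1)C(=O)C2`, in a functional assay on HepG2 cells (Homo sapiens) for inhibition, read by MTT assay, with a stated time of 24 h (on this read-out lower numbers stand for stronger inhibition and higher numbers for weaker inhibition), gives 150 nM.
Compound 2, `CC1(C)[C@H]2CC[C@]1(C)N(Cc1cn(-c3ccccc3F)nn1)C(=O)C2`, gives in this assay 60 nM.
Compound 3, `CC1(C)[C@H]2CC[C@]1(C)N(Cc1cn(-c3ccccc3)nn1)C(=O)C2`, gives in this assay 90 nM.

Compound 2 carries the lowest of the three numbers in this assay. Compound 3 sits nearest to it, with a 1.5-fold higher number from compound 2 to compound 3 (0.18 log units; within the scatter), a gap within the scatter, so the two cannot be ranked against each other. Compound 1 is the furthest away, and the step of a 2.5-fold lower number from compound 1 to compound 2 (0.40 log units; beyond the scatter) lies beyond the scatter.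

Compound 4, `Cc1ccccc1-n1cc(CN2C(=O)C[C@@H]3CC[C@@]2(C)C3(C)C)nn1`, is not yet measured. Its difference from compound 2 is methyl in place of fluoro on an aromatic carbon.

Going by the values given here, two measured steps bear on this change, both at the same aromatic carbon. The step of a 2.5-fold lower number from compound 1 to compound 2 (0.40 log units; beyond the scatter) shows that bromo in that place gave a clearly higher number than fluoro. The step of a 1.5-fold higher number from compound 2 to compound 3 (0.18 log units; within the scatter) shows that hydrogen in that place left the number within the scatter of fluoro. Methyl is neither of these, so the expectation is a modest rise in the number, possibly within the scatter but leaning toward the direction that bromo set.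

For compound 4 the expected value in this assay is 110 nM, with a range from 50 nM to 250 nM, which means an expected step of a 1.8-fold higher number from compound 2 to compound 4 (0.26 log units; within the scatter).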

Compound 4, half-maximal inhibitory concentration: 150 nM
The estimate for compound 4 lay 1.4-fold (0.13 log units) below the measured number; measured number inside the range.
By their numbers in this assay, from the lowest: compounds 2, 3, 1 and 4 (each within the scatter of the next, the first and the last beyond it).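

Compound 4 shows that bromo is not alone in parting from fluoro on this aromatic carbon, ortho to a large group: in this assay methyl in place of fluoro gives a 2.5-fold higher number from compound 2 to compound 4 (0.40 log units; beyond the scatter), the same size of step that separated bromo from fluoro. Methyl and bromo cannot be told apart here (no change at the digits printed from compound 1 to compound 4 (within the scatter)), and methyl also stays within the scatter of hydrogen (a 1.7-fold higher number from compound 3 to compound 4 (0.22 log units; within the scatter)), so among these four groups only the fluoro and hydrogen pair and the hydrogen, methyl and bromo set overlap, and fluoro is separated only from methyl and bromo. Nothing at hand accounts for this grouping of the four compounds.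

From the compounds shown here alone, what stays open is whether any group at this place can move the number beyond the scatter of hydrogen in either direction, as a methoxy group, a chloro group or an amine might be tested to show. Also open, going by these compounds, is whether the gap between 2-fluorophenyl and 2-methylphenyl would hold with the same groups elsewhere on the aromatic ring, or on a core other than the shared one.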